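Oxetane-bearing amide tested on the shared core

The source may report more compounds than this note shows. Statements on the series, on what has been measured and on what is new or still open speak of the compounds shown alone.

Measured compounds:
compound 1 `C[C@@H](NC(=O)c1ccc(C#Cc2ccccc2)cn1)C(C)(C)O` gives 43.2%
compound 2 `Cc1nc(C#Cc2cccc(F)c2)ccc1C(=O)N[C@H](C)C(C)(C)O` gives 9.2%
compound 3 `CC(C)[C@H](C)NC(=O)c1ccc(C#Cc2cccc(F)c2)cn1` gives 13.1%

The three compounds were measured in an ADME assay on HEK293 cells for agonist activity at metabotropic glutamate receptor 5 (Rattus norvegicus), read by fluorescence and calcium flux; on this read-out lower numbers stand for smaller maximal responses and higher numbers for larger maximal responses. Among the three numbers compound 3 holds the second highest place. Its nearest neighbour is compound 2, whose number lies a little lower but within the scatter of repeated measurements, so no order between compound 2 and compound 3 can be claimed. The furthest is compound 1, whose number lies higher by an amount that is beyond the scatter.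

The next compound, compound 4 `CC1(CCNC(=O)c2ccc(C#Cc3cccc(F)c3)cn2)COC1`, has not yet been measured in this assay. It differs from compound 3 in one place: 2-(3-methyloxetan-3-yl)ethyl in place of 1,2-dimethylpropyl on an amide-type nitrogen. The 1,2-dimethylpropyl group leaves the amide-type nitrogen whose other neighbour is the carbonyl carbon, and 2-(3-methyloxetan-3-yl)ethyl enters there, bringing one four-membered non-aromatic ring with one hetero atom and one hydrogen-bond acceptor.

Among the compounds with values here, no measured pair here shows this particular exchange, so the size of the step in this assay cannot be read from the data. The step from compound 3 to compound 4 is expected to be small, with no clear direction beyond the scatter, and is estimated at a number 1.9 percentage points higher from compound 3 to compound 4 (within the scatter). For compound 4 in this assay the estimate is 15%, with a range from 3% to 35%.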

Compound 4, largest response reached (reported as efficacy), in percent of the reference or control that the assay uses: 16.3%
For compound 4 the middle estimate is 1.3 percentage points below the measured one, and the stated range covers the measured number.
By their numbers in this assay, from the lowest: compounds 2, 3 and 4 (each within the scatter of the next); then compound 1.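

In this assay, 2-(3-methyloxetan-3-yl)ethyl in place of 1,2-dimethylpropyl on an amide-type nitrogen gives a number 3.2 percentage points higher from compound 3 to compound 4 (within the scatter). Within the data shown here, this is the first pair that differs in one place, and it shows that this position takes a substituent with one four-membered non-aromatic ring, one hydrogen-bond acceptor and no defined stereocentre without a shift in maximal response that stands out from the scatter, even though the group is larger by the count of heavy atoms. No measurement at hand accounts for the size of this step.

Going by these compounds, the pair gives a single exchange at this nitrogen, so it remains open whether any other substituent there, such as a longer chain, a chain ending in a primary amine or one ending in a carboxylic acid, would move the response beyond the scatter. On these data alone, it is equally open whether 2-(3-methyloxetan-3-yl)ethyl would behave in the same way on the core of compound 1, which carries a different amide substituent and no fluorine on its terminal ring.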